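From pyrrolidin-1-yl to piperidin-1-yl on the shared core

A few compounds are considered here, and "the series" means these few. Any claim that something is new, unique, unknown or untested is made for them only; others in the source may bear on it.

- Compound 1 `CN(C)C12CC(=O)C(C(c3ccccc3)C1)C(c1ccccc1)C2`: 24600 nM
- Compound 2 `O=C1CC2(N3CCCC3)CC(c3ccccc3)C1C(c1ccccc1)C2`: 26500 nM

In an ADME assay on L6 cells (Rattus norvegicus) for cytotoxicity (a higher number here means a weaker inhibitor, a lower number a stronger inhibitor), compound 2 gives 26500 nM, level within the scatter with compound 1 at 24600 nM. Compound 3 `O=C1CC2(N3CCCCC3)CC(c3ccccc3)C1C(c1ccccc1)C2` has piperidin-1-yl in place of pyrrolidin-1-yl on a saturated ring carbon. Within the data shown here, only one measured step bears on this, the swap of dimethylamino for pyrrolidin-1-yl at the same carbon, which gave a 1.1-fold higher number from compound 1 to compound 2 (0.03 log units; within the scatter). That is a single small step, so no change beyond the scatter is expected in this assay, in either direction. The expected step is a 1.1-fold lower number from compound 2 to compound 3 (0.04 log units; within the scatter). Compound 3 is estimated at 24000 nM, with an expected range of 11000 nM to 50000 nM.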

Compound 3, half-maximal inhibitory concentration: 46900 nM
Compound 3: the middle estimate sits 2.0-fold (0.29 log units) below what was measured, within the range that was stated.
By their numbers in this assay, from the lowest: compounds 1, 2 and 3 (each within the scatter of the next).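

In this assay piperidin-1-yl in place of pyrrolidin-1-yl gives a 1.8-fold higher number from compound 2 to compound 3 (0.25 log units; within the scatter) and in place of dimethylamino gives a 1.9-fold higher number from compound 1 to compound 3 (0.28 log units; within the scatter) at the same carbon. A six-membered ring on this saturated ring carbon therefore reads level with the five-membered ring and the open dimethylamino group, so all three amines sit within the scatter of each other. Nothing available explains these numbers. As far as these compounds go, what remains open is whether a morpholine, a primary amine or a hydroxyl group on this carbon would stay level with these three.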